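Swapping the aryl group on the anilinic nitrogen of compound 1

A few compounds are considered here, and "the series" means these few. Any claim that something is new, unique, unknown or untested is made for them only; others in the source may bear on it.

Compound 1 `COc1cc(N(CC2CC2)c2cccc(C(F)(F)F)c2)cnc1C(=O)[C@H]1C[C@@H]1C(=O)O` is the reference point of this small set. In an assay on isolated protein for inhibition of leukotriene C4 synthase (Homo sapiens), read by LC-MS, with stated times of 45 min and 20 min (on this read-out lower numbers stand for stronger inhibition and higher numbers for weaker inhibition), compound 1 gives 52.4 nM, and the single comparator, compound 2 `CCCN(c1cccc(C(F)(F)F)c1)c1cnc(C(=O)[C@H]2C[C@@H]2C(=O)O)c(OC)c1`, gives 58.4 nM in this assay. Within the data shown here, the one measured step, a 1.1-fold higher number from compound 1 to compound 2 (0.05 log units; within the scatter), changes only the saturated chain on the nitrogen, so the two compounds cannot be told apart on these numbers; compound 1 simply stands beside compound 2.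

Compound 3 `COc1cc(N(CC2CC2)c2cc(Cl)ccc2F)cnc1C(=O)[C@H]1C[C@@H]1C(=O)O` keeps that nitrogen and its cyclopropylmethyl chain and alters the other substituent instead: 5-chloro-2-fluorophenyl in place of 3-(trifluoromethyl)phenyl on a nitrogen on an aromatic ring. Among the measured compounds shown here, no measured step touches this aryl group, since the step from compound 1 to compound 2 concerns the chain alone and says nothing about the ring. For the measured compounds named here, with no precedent, a small shift in this assay is expected, most likely toward a somewhat higher number because the trifluoromethyl-bearing ring of compound 1, at 52.4 nM, is the only aryl group tried here. The step from compound 1 to compound 3 is estimated as a 1.5-fold higher number from compound 1 to compound 3 (0.18 log units; within the scatter). Compound 3 is therefore expected to give about 80 nM in this assay, within a range from 25 nM to 250 nM.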

Compound 3, half-maximal inhibitory concentration: 34.3 nM
Compound 3: the middle estimate sits 2.3-fold (0.37 log units) above what was measured; measured number inside the range.
By their numbers in this assay, from the lowest: compounds 3, 1 and 2 (each within the scatter of the next).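

In this assay, among these compounds, the exchange of the aryl group gives a 1.5-fold lower number from compound 1 to compound 3 (0.18 log units; within the scatter), the first step in this set that touches the ring rather than the saturated chain on the nitrogen. It shows that 3-(trifluoromethyl)phenyl, with 10 heavy atoms, and 5-chloro-2-fluorophenyl, with 8 heavy atoms and a different set of halogens, cannot be told apart at this position, so the number does not depend on keeping the trifluoromethyl group; together with a 1.1-fold higher number from compound 1 to compound 2 (0.05 log units; within the scatter), each of the two substituents on this nitrogen has now been changed once, and neither step leaves the scatter. No measured information on these compounds explains why the two aryl groups read alike.

What the compounds leave open is whether any aryl group at this position moves the number beyond the scatter, for instance an unsubstituted phenyl, a phenyl carrying a nitrile or a methoxy group, or a pyridine ring in place of the phenyl. As far as these compounds go, it also remains open how far the saturated chain can be varied with 5-chloro-2-fluorophenyl on the nitrogen, for example with a longer chain such as butyl, and whether the chlorine or the fluorine alone would give a similar number.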